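A few compounds are considered here, and "the series" means these few. Any claim that something is new, unique, unknown or untested is made for them only; others in the source may bear on it.

For the measured compounds named here, only two compounds have been measured so far in an ADME assay for permeability, using PAMPA, at pH 7.4 (a higher number here means that the compound crosses the layer faster, a lower number that the compound crosses the layer more slowly), and the picture is still thin. There compound 2 (`O=C(Nc1cccc(-c2nc3ccccc3s2)c1)c1cc([N+](=O)[O-])ccc1Cl`) gives 12 10^-6 cm/s and stands lowest of the two, well beyond the scatter from compound 1 (`COc1ccc(-c2nc3ccccc3o2)cc1NC(=O)c1cc([N+](=O)[O-])ccc1Cl`), which gives 274 10^-6 cm/s on the same scale. Compound 3 (`COc1ccc(-c2nc3ccccc3s2)cc1NC(=O)c1cc([N+](=O)[O-])ccc1Cl`) follows from compound 2 by one change: methoxy in place of hydrogen on an aromatic carbon. Going by the values given here, no step between measured compounds shows this change alone, so the expectation rests on little. Among the compounds with values here, compound 1 also bears a methoxy and gives 274 10^-6 cm/s as the only guide, so a rise beyond the scatter is expected, probably stopping short of compound 1. The expected step is a 7.5-fold higher number from compound 2 to compound 3 (0.88 log units; beyond the scatter) in this assay and remains an estimate. Compound 3 is expected at 90 10^-6 cm/s with an estimated range from 25 10^-6 cm/s to 320 10^-6 cm/s in apparent permeability.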

Compound 3, apparent permeability: "below limit of detection" (no number reported)
For compound 3 the study gives words and no number; there is nothing to compare the estimate with.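

In this assay, for the compounds shown here, compound 3 is reported in words and without a number, so no step from compound 2 to compound 3 can be read. The compounds shown leave open how far methoxy in place of hydrogen shifts this read-out. No evidence on hand bears on this result.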